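Straight Butyl Chain in Place of a Branched One

The compounds below may be only part of what the source reports. "The series", "measured", "known", "first", "only" and "open" are said of these compounds alone.

Compound 1 `CCc1nc(C(=O)OC)nn1-c1ccc(F)cc1` gives 15800 nM in a functional assay on NPC-TW01 cells (Homo sapiens) for inhibition, read by MTT assay, with a stated time of 72 h; a lower number here means a stronger inhibitor of growth, a higher number a weaker inhibitor of growth. Compound 2 `COC(=O)c1nc(C(C)C)n(-c2ccc(F)cc2)n1` reaches only the limit of this assay, > 100000 nM. Among the compounds with values here, the single measured step shows an at least 6.3-fold higher number from compound 1 to compound 2 (0.80 log units; beyond the scatter), so compound 2 stands at the weak end of what has been seen. Compound 3 `CCCCc1nc(C(=O)OC)nn1-c1ccc(F)cc1` carries butyl in place of isopropyl on an aromatic carbon. That step concerns a different change and does not settle this one, yet a move back toward the number of compound 1 seems plausible, so compound 3 is expected to show an at least 3.3-fold lower number from compound 2 to compound 3 (0.52 log units; beyond the scatter). Compound 3 is estimated at 30000 nM, with a range from 8000 nM to 150000 nM.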

Compound 3, concentration for 50% growth inhibition: > 100000 nM
Compound 3: only a limit was reported; the forecaster's own chance of this, stated with the estimate: 35%; middle value at least 3.3-fold (0.52 log units) away from the limit.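

In this assay compound 3 gives > 100000 nM, which is a limit of the assay and not a number. Replacing the ethyl group with butyl gives an at least 6.3-fold higher number from compound 1 to compound 3 (0.80 log units; beyond the scatter), so the loss of growth inhibition seen with branched isopropyl also appears with a straight chain. Butyl and isopropyl cannot be ranked, because the step between them cannot be read: the limit of > 100000 nM in this assay, at which 2 of the 3 values shown sit.

From the compounds shown here alone, it remains open whether a methyl group or a propyl chain on this aromatic carbon would match compound 1 at 15800 nM or improve on it. Going by these compounds, how an amine at this place would behave also remains unknown.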